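Estimating a hydrazide analogue in a nucleoside series

The source may report more compounds than this note shows. Statements on the series, on what has been measured and on what is new or still open speak of the compounds shown alone.

Measured so far:
compound 1 `Cc1nc2c(N)ncnc2n1[C@@H]1O[C@H](C[S+](C)C)[C@@H](O)[C@H]1O`, 3000 nM;
compound 2 `CCc1nc2c(N)ncnc2n1[C@@H]1O[C@H](CN(C)CCC(N)=O)[C@@H](O)[C@H]1O`, 4000 nM;
compound 3 `Cc1nc2c(N)ncnc2n1[C@@H]1O[C@H](CN(C)CCN)[C@@H](O)[C@H]1O`, 88000 nM.

All three share the same core and were tested in an assay on isolated protein for inhibition of S-adenosylmethionine decarboxylase proenzyme (Homo sapiens); on this read-out lower numbers stand for stronger inhibition and higher numbers for weaker inhibition. Compound 1 gives 3000 nM and compound 2 gives 4000 nM, while compound 3 gives 88000 nM, the highest of the three numbers, that is the weakest inhibition seen here. The only step counted among these compounds runs a 29-fold higher number from compound 1 to compound 3 (1.47 log units; beyond the scatter), which shows how much ground compound 3 has lost against compound 1.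

Compound 4 `Cc1nc2c(N)ncnc2n1[C@@H]1O[C@H](CN(C)CC(=O)NN)[C@@H](O)[C@H]1O` differs from compound 3 by aminocarbamoyl in place of aminomethyl on a saturated chain carbon bound to an amine nitrogen. Within the data shown here, no measured step matches this change directly. What can be said is that compound 2, whose chain ends in a carbonyl-bearing group, sits far lower than compound 3, and compound 1 sits lower still, so the chain end of compound 3 is the weakest variant on record here. Going by these compounds, since compound 4 also carries a carbonyl-bearing chain end, a clearly lower number than compound 3 is expected, roughly in the region of compound 2, though the hydrazide is untested and the uncertainty is wide. The expected step is an 18-fold lower number from compound 3 to compound 4 (1.25 log units; beyond the scatter), and compound 4 is estimated at 5000 nM, with a range from 800 nM to 30000 nM.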

Compound 4, half-maximal inhibitory concentration: 31000 nM
For compound 4 the middle estimate is 6.2-fold (0.79 log units) below the measured one; the measured number lies above the stated range.
By their numbers in this assay, from the lowest: compounds 1 and 2 (each within the scatter of the next); then compound 4; then compound 3.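

In this assay, exchanging aminomethyl for aminocarbamoyl gives a 2.8-fold lower number from compound 3 to compound 4 (0.45 log units; beyond the scatter), so adding a carbonyl to this chain end brings back only a modest part of the lost inhibition. The gap to the small sulfur-bearing group of compound 1 stays wide, at a 10-fold higher number from compound 1 to compound 4 (1.01 log units; beyond the scatter), which means that neither of the two chains directly comparable with that group, in compound 3 and compound 4, comes close to it at this position. No measurement offered here gives a reason for the size of either step.

The compounds shown do not separate the part played by the carbonyl from that of the extra nitrogen in aminocarbamoyl, and a carboxylic acid at the same chain end would help to tell the two apart. Compound 2 reaches 4000 nM, but it carries ethyl where compound 3 and compound 4 carry methyl and also has a different chain, so its number cannot be credited to either change alone.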